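Chain Extension on the Shared Core and CYP2B1 Inhibition

A few compounds are considered here, and "the series" means these few. Any claim that something is new, unique, unknown or untested is made for them only; others in the source may bear on it.

The series is followed in an ADME assay on microsomes from liver for inhibition of cytochrome P450 2B1 (Rattus norvegicus); on this read-out higher numbers stand for weaker inhibition and lower numbers for stronger inhibition. Compound 1 `CC(=O)Nc1ccc2[nH]c(C)nc2c1` gives 1260000 nM in this assay, and compound 2 `CCCCC(=O)Nc1ccc2[nH]c(C)nc2c1` gives 417000 nM. The change between them, (propyl in place of hydrogen on a saturated chain carbon bound to a carbonyl carbon), gives a 3.0-fold lower number from compound 1 to compound 2 (0.48 log units; beyond the scatter). Among the measured compounds shown here, compound 3 `CCCCc1nc2cc(C)c(C)cc2[nH]1` carries a different core, and the difference between its core and that of compound 1 is not broken down here; in this assay compound 3 gives 55000 nM, the lowest of the three numbers so far. Compound 4 `CCCCCCCc1nc2cc(C)c(C)cc2[nH]1` is the one not yet measured. It differs from compound 3 by propyl in place of hydrogen on a saturated chain carbon, four bonds along the chain from an aromatic carbon. For the measured compounds named here, this is the same kind of change as the one from compound 1 to compound 2, but not the same: there the propyl enters on a saturated chain carbon bound to a carbonyl carbon, here on a saturated chain carbon four bonds along the chain from an aromatic carbon. Going by the values given here, a step of about a 3.1-fold lower number from compound 3 to compound 4 (0.49 log units; beyond the scatter) is expected in this assay, resting on a 3.0-fold lower number from compound 1 to compound 2 (0.48 log units; beyond the scatter) as the only direct precedent for this change. For compound 4 the estimate in this assay is 18000 nM, with a range from 6000 nM to 55000 nM.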

Compound 4, half-maximal inhibitory concentration: 44700 nM
Compound 4: the middle estimate sits 2.5-fold (0.40 log units) below what was measured; low and high end bracket the measured number.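

Set side by side in this assay, the two readings of this change do not separate the cores: the same change on two cores in this assay, a 3.0-fold lower number (0.48 log units; beyond the scatter) from compound 1 to compound 2 and a 1.2-fold lower number (0.09 log units; within the scatter) from compound 3 to compound 4, 2.5-fold (0.39 log units) apart, within the scatter of two such steps. Taken alone, a 3.0-fold lower number from compound 1 to compound 2 (0.48 log units; beyond the scatter) lies beyond the scatter while a 1.2-fold lower number from compound 3 to compound 4 (0.09 log units; within the scatter) does not, so only the first pair shows a change in the read-out, and the gap between the two steps is too small to make this a difference between cores. The two pairs therefore show neither that the change carries over at one fixed size nor that its size depends on the core, and the place of entry also differs, on a saturated chain carbon bound to a carbonyl carbon in one pair and four bonds along the chain from an aromatic carbon in the other.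

Open, as far as these compounds go, is how a chain ending in an amine or a carboxylic acid would read in this assay in place of the propyl on either core. Also open, from the compounds shown here alone, is whether a longer chain would give a step beyond the scatter on the core of compound 3.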